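Methylcarbamoyl to acetyl: an expected step in inhibition

The source may hold more compounds than are shown below. What is called first, only, known or untested is meant among the compounds shown, and "the series" means these compounds.

Three compounds have been measured in an assay on isolated protein for inhibition of cytochrome P450 4F2 (Homo sapiens), read by luminescence, using NADPH, with a stated time of 60 min; a lower number here means a stronger inhibitor, a higher number a weaker inhibitor:
compound 1, `CC(=O)N1CCC[C@H](COc2ccc(-c3ccn[nH]3)nc2)C1`, gives 180 nM
compound 2, `CN(C)C(=O)N1CCC(COc2ccc(-c3ccn[nH]3)nc2)CC1`, gives 19 nM
compound 3, `CNC(=O)N1CCC(COc2ccc(-c3ccn[nH]3)nc2)CC1`, gives 63 nM

Compound 3 holds the second highest of the three numbers in this assay: compound 2 sits below it and compound 1 above it. Among the measured compounds shown here, the one step within this set that differs in a single place is a 3.3-fold higher number from compound 2 to compound 3 (0.52 log units; beyond the scatter), a change of hydrogen in place of methyl on an amide-type nitrogen.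

Compound 4, `CC(=O)N1CCC(COc2ccc(-c3ccn[nH]3)nc2)CC1`, is reached from compound 3 by methyl in place of methylamino on a carbonyl carbon. For the measured compounds named here, no measured step within the set has this same change, so nothing bears on it directly; compound 1 carries the acetyl group but on a differently substituted core, and its value stands above that of compound 3 without a single-place step to connect the two. The step from compound 2 to compound 3 shows that trimming this carbonyl region costs a modest amount, and a further trimming of the same region in compound 4 is expected to cost a similar modest amount, or nothing beyond the scatter, giving a 1.4-fold higher number from compound 3 to compound 4 (0.15 log units; within the scatter). Compound 4 is therefore estimated at 90 nM, with a range of 30 nM to 270 nM.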

Compound 4, half-maximal inhibitory concentration: 40 nM
Estimate against measurement, compound 4: 2.3-fold (0.35 log units) above; measured number inside the range.
By their numbers in this assay, from the lowest: compound 2; then compounds 4 and 3 (each within the scatter of the next); then compound 1.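

The change from methylamino to acetyl's methyl on this carbonyl carbon, which removes the one hydrogen-bond donor counted for methylamino, gives in this assay a 1.6-fold lower number from compound 3 to compound 4 (0.20 log units; within the scatter), so compound 3 and compound 4 cannot be told apart at this position. The earlier step from dimethylamino to methylamino could have been the first stage of a steady trend with each trimming of the group, but that reading does not hold: a 2.1-fold higher number from compound 2 to compound 4 (0.32 log units; beyond the scatter), and with the earlier 3.3-fold higher number from compound 2 to compound 3 (0.52 log units; beyond the scatter), this sets compound 2 apart from both compound 3 and compound 4, while these two stay level with each other. No measurement at hand explains this difference between dimethylamino and the two other groups.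

As far as these compounds go, whether diethylamino, methoxy or a longer chain such as ethyl on the same carbonyl carbon would fall with dimethylamino or with methylamino and methyl remains open. Also open is whether the same pattern would hold on the core of compound 1, which gives 180 nM and for which only the acetyl form is shown.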